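Propylamide Replaces Diethylamide in the Paw Edema Series

A few compounds are considered here, and "the series" means these few. Any claim that something is new, unique, unknown or untested is made for them only; others in the source may bear on it.

Compound 3 `CCN(CC)C(=O)CC1CCc2cc(OC)c(OC)cc21` carries the largest of the three numbers in a functional assay on the whole organism (strain Wistar) for inhibition, with Rattus norvegicus as the target, read by paw edema, with stated times of 60 min and 4 h, at a dose of 100 mg/kg by the oral route (a higher number here means more inhibition at the dose given (going by the name of the read-out), a lower number less inhibition), giving 37.5%, though its gap to compound 2 lies within the scatter. Compound 2 `COc1cc2c(cc1OC)C(CC(=O)N(C)C)CC2` gives 35.9%, and compound 1 `COc1cc2c(cc1OC)C(CC(=O)O)CC2` gives 23.9%. Compound 4 `CCCNC(=O)CC1CCc2cc(OC)c(OC)cc21` differs from compound 3 in one place: propylamino in place of diethylamino on a carbonyl carbon. Compound 4 keeps the amide; the acid-to-amide steps a number 12 percentage points higher from compound 1 to compound 2 (beyond the scatter) and a number 13.6 percentage points higher from compound 1 to compound 3 (beyond the scatter), both beyond the scatter, do not bear on it. Going by the values given here, the one step between two amides, a number 1.6 percentage points higher from compound 2 to compound 3 (within the scatter), bears on it directly and lay within the scatter. No step beyond the scatter is therefore expected. Compound 4 is estimated at 34%, within 22% to 46%, an expected step of a number 3.5 percentage points lower from compound 3 to compound 4 (within the scatter).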

Compound 4, a percentage reported as inhibition, in the whole organism at one dose (the size of the read-out at that dose, not a potency): 26.6%
For compound 4 the middle estimate is 7.4 percentage points above the measured one, and the stated range covers the measured number.
By their numbers in this assay, from the lowest: compounds 1, 4, 2 and 3 (each within the scatter of the next, the first and the last beyond it).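

In this assay, the groups on the amide nitrogen are no longer interchangeable: propylamino in place of diethylamino gives a number 10.9 percentage points lower from compound 3 to compound 4 (beyond the scatter), whereas the step with dimethylamino as the starting group gives a number 9.3 percentage points lower from compound 2 to compound 4 (within the scatter). The gain over the acid seen with the two tertiary amides does not clearly carry over to this amide, which gives a number 2.7 percentage points higher from compound 1 to compound 4 (within the scatter). Nothing at hand bears on the cause of these steps. As far as these compounds go, whether the fall from compound 3 goes with the amide hydrogen or with the chain stays open; a dipropylamino group on the carbonyl carbon would speak to that.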